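The source may hold more compounds than are shown below. What is called first, only, known or untested is meant among the compounds shown, and "the series" means these compounds.

Measured so far:
- compound 1 `COc1cc(C(=O)c2sc(-c3ccc(C)cc3)cc2N)cc(OC)c1OC`: 16 nM
- compound 2 `COc1cc(C(=O)c2sc(-c3cc(OC)c(OC)c(OC)c3)cc2N)cc(OC)c1OC`: 1200 nM
- compound 3 `COc1cc(C(=O)c2sc(-c3ccncc3)cc2N)cc(OC)c1OC`: 88 nM

All three values come from a functional assay on MOLT-4 cells (Homo sapiens) for antiproliferative activity; a higher number here means a weaker inhibitor, a lower number a stronger inhibitor. Compound 3 stands second highest of these three numbers: it sits well above compound 1, with a 5.5-fold higher number from compound 1 to compound 3 (0.74 log units; beyond the scatter), and below compound 2, whose number is higher still, as the two values show.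

The next compound, compound 4 `COc1ccc(-c2cc(N)c(C(=O)c3cc(OC)c(OC)c(OC)c3)s2)cc1OC`, differs from compound 3 in one place: 3,4-dimethoxyphenyl in place of pyridin-4-yl on an aromatic carbon. For the measured compounds named here, no measured step covers exactly this exchange. The nearest guide is the pair of compounds 1 and 2, which share the core and differ only in the group on that carbon: the 4-methylphenyl compound gives a low number, the 3,4,5-trimethoxyphenyl compound a much higher one. A 3,4-dimethoxyphenyl group carries fewer methoxy groups than that, so compound 4 is expected to land between compound 3 and compound 2, with a moderate rise in this assay of a 3.4-fold higher number from compound 3 to compound 4 (0.53 log units; beyond the scatter). Compound 4 is therefore estimated at 300 nM, within a range from 80 nM to 1200 nM.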

Compound 4, half-maximal inhibitory concentration: 20 nM
Beside the measured number, compound 4's estimate is 15-fold (1.18 log units) above it; the whole stated range lies above it.
By their numbers in this assay, from the lowest: compounds 1 and 4 (each within the scatter of the next); then compound 3; then compound 2.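

In this assay, a single methoxy group makes a large difference at this carbon: hydrogen in its place, turning the 3,4,5-trimethoxyphenyl group into the 3,4-dimethoxyphenyl group, gives a 60-fold lower number from compound 2 to compound 4 (1.78 log units; beyond the scatter). Among these compounds, then, two methoxy groups on this ring are well tolerated and three are not, with the 3,4-dimethoxyphenyl group ahead of pyridin-4-yl by a 4.4-fold lower number from compound 3 to compound 4 (0.64 log units; beyond the scatter) and not separable from 4-methylphenyl at a 1.3-fold higher number from compound 1 to compound 4 (0.10 log units; within the scatter). Nothing measured here gives a reason for the drop seen with the third methoxy group.

Going by these compounds, what remains open is how much of this pattern depends on the number of methoxy groups and how much on where they sit. A 4-methoxyphenyl or a 3,5-dimethoxyphenyl group on this carbon would help separate the two, and a 4-aminophenyl group would show how an amine fares here.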